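This account rests on a few compounds, and the source may have more. Where it says the series, first, only, none or still open, it means among the compounds named here.

Compound 1 `CCc1nc(N)nc(N)c1-c1ccc(NCc2ccc(S(C)(=O)=O)cc2)cc1` and compound 2 `CCc1nc(N)nc(N)c1-c1ccc(NCc2ccc([N+](=O)[O-])cc2)cc1` share a core and differ at a single aromatic carbon: methylsulfonyl in place of nitro on an aromatic carbon. In a functional assay on CHOK cells for antagonist activity at growth hormone secretagogue receptor type 1 (Homo sapiens), read by calcium flux (a higher number here means a weaker inhibitor, a lower number a stronger inhibitor), compound 2 gives 23 nM, and compound 1 gives 12 nM; the step is a 1.9-fold lower number from compound 2 to compound 1 (0.28 log units; within the scatter), so the two numbers cannot be told apart with confidence.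

Compound 3 `CCc1nc(N)nc(N)c1-c1ccc(CNc2ccc([N+](=O)[O-])cc2)cc1` is built from the same atoms as compound 2, joined differently; the difference between the two cores is not broken down here. In this assay compound 3 gives 190 nM, the highest of the three numbers, and its gaps to both compound 2 and compound 1 lie beyond the scatter.

Compound 4 `CCc1nc(N)nc(N)c1-c1ccc(CNc2ccc(S(C)(=O)=O)cc2)cc1` has not yet been measured. It differs from compound 3 by methylsulfonyl in place of nitro on an aromatic carbon, the same change, in the same place, that separates compound 2 from compound 1. That change has been seen only once, on the core of compound 2, where it stayed within the scatter. The expected step is a 1.9-fold lower number from compound 3 to compound 4 (0.28 log units; within the scatter), chosen to match that earlier pair, with the caution that a single pair on a different core is thin ground. On that basis compound 4 is expected to give about 100 nM in this assay, with a likely range from 45 nM to 250 nM.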

Compound 4, half-maximal inhibitory concentration: 120 nM
For compound 4 the middle estimate is 1.2-fold (0.08 log units) below the measured one; the measured number falls inside the stated range.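

In this assay, putting methylsulfonyl in place of nitro on an aromatic carbon gives a 1.6-fold lower number from compound 3 to compound 4 (0.20 log units; within the scatter), so these two numbers cannot be told apart with confidence. Set beside the earlier pair, the change looks much the same on both cores: the same change on two cores in this assay, a 1.9-fold lower number (0.28 log units; within the scatter) from compound 2 to compound 1 and a 1.6-fold lower number (0.20 log units; within the scatter) from compound 3 to compound 4, 1.2-fold (0.08 log units) apart, within the scatter of two such steps. This shows that, in these two pairs, the swap leaves the number within the usual scatter whichever core carries it, so a result seen on one core was a fair guide to the other; it does not show that the change has any real effect on the number, that the two steps are truly equal in size, or that the same would hold on a third core or in a different assay.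

Across the four compounds, only methylsulfonyl and nitro appear at this place on the aromatic ring, so it stays open whether a nitrile, a carboxylic acid or an amine there would also leave the number within the scatter or move it clearly beyond it. The ethyl group on the shared core is also the same in all four compounds, which leaves open what a longer chain in its place would do.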